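The source may hold more compounds than are shown below. What is called first, only, known or untested is meant among the compounds shown, and "the series" means these compounds.

Three compounds sharing one core have been examined in a functional assay (trachea) with Rattus norvegicus as the target; on this read-out higher numbers stand for higher potency (the scale is a negative logarithm) and lower numbers for lower potency. Compound 1 `COc1ccc2c(c1)C(n1ccccc1=O)=CC(C)(C)O2` gives 5.99 in this assay. Compound 2 `CC1(C)C=C(n2ccccc2=O)c2cc(C(=O)c3ccccc3)ccc2O1` gives 6.21, and compound 3 `CC1(C)C=C(n2ccccc2=O)c2cc(C=O)ccc2O1` gives 6.14. All three values sit within the scatter of one another, with compound 1 at the foot of that narrow span: the step is a number 0.22 log units higher from compound 1 to compound 2 (within the scatter) and a number 0.15 log units higher from compound 1 to compound 3 (within the scatter), while between the two larger groups it is a number 0.07 log units lower from compound 2 to compound 3 (within the scatter).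

Compound 4 `CC1(C)C=C(n2ccccc2=O)c2cc(OC(=O)Nc3ccccc3)ccc2O1` is the next member, not yet measured in this assay. It differs from compound 1 by phenylcarbamoyl in place of methyl on an oxygen on an aromatic ring. The two steps that bear on this change are those from compound 1 to compound 2 and from compound 1 to compound 3, both of which rework the same aromatic position and both of which stayed within the scatter. On that basis no step beyond the scatter is expected for compound 4, and its value in this assay is estimated at 6.1, with a range from 5.6 to 6.6, corresponding to an expected step of a number 0.11 log units higher from compound 1 to compound 4 (within the scatter).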

Compound 4, logarithm of the reciprocal of the active concentration, log(1/C): 4.89
Compound 4: the middle estimate sits 1.21 log units above what was measured; measured number below the stated range.
By their numbers in this assay, from the lowest: compound 4; then compounds 1, 3 and 2 (each within the scatter of the next).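

In this assay, the step of a number 1.10 log units lower from compound 1 to compound 4 (beyond the scatter) shows that this aromatic position is not indifferent to every change, as the steps to compound 2 and compound 3 alone might have suggested. A phenyl ring as such does not account for the change in any simple way, since compound 2 also carries one and gives 6.21, whereas in compound 4 the ring is held through a carbamate on the oxygen, with a hydrogen-bond donor entering alongside it. No measurement on hand bears on why the number falls.

The compounds shown leave open whether the fall follows the phenyl ring, the amide hydrogen or the carbamate link itself. A methylcarbamoyl or a benzoyl group on the same oxygen would separate these, as would a dimethylcarbamoyl group.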